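A few compounds are considered here, and "the series" means these few. Any claim that something is new, unique, unknown or untested is made for them only; others in the source may bear on it.

Three amides built on one shared core have been measured in an ADME assay on microsomes from liver (Homo sapiens) for pharmacokinetics, using NADPH, with a stated time of 30 min, tested at 1 uM; a higher number here means faster removal of the compound, a lower number slower removal. In this assay compound 1 `CNC(=O)c1c(-c2ccccc2)c([C@H](C)Nc2ncnc(N)c2C#N)nc2ccc(F)cc12` gives < 14 mL.min-1.g-1, which is a limit of the assay and not a number. Compound 2 `C[C@H](Nc1ncnc(N)c1C#N)c1nc2ccc(F)cc2c(C(=O)N(C)C)c1-c1ccccc1` gives 198 mL.min-1.g-1. Compound 3 `CC(C)NC(=O)c1c(-c2ccccc2)c([C@H](C)Nc2ncnc(N)c2C#N)nc2ccc(F)cc12` gives 51 mL.min-1.g-1, the lower of the two actual numbers.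

The next structure, compound 4 `C[C@H](Nc1ncnc(N)c1C#N)c1nc2ccc(F)cc2c(C(=O)N2CC(O)C2)c1-c1ccccc1`, has 3-hydroxyazetidin-1-yl in place of isopropylamino on a carbonyl carbon. Earlier changes at this amide moved the read-out clearly. The large step is an at least 14-fold higher number from compound 1 to compound 2 (1.15 log units; beyond the scatter), the step of at least modest size is an at least 3.6-fold higher number from compound 1 to compound 3 (0.56 log units; beyond the scatter), and the modest step, the closest guide here, is a 3.9-fold lower number from compound 2 to compound 3 (0.59 log units; beyond the scatter).

Compound 4 resembles compound 2 198 mL.min-1.g-1 in having no amide hydrogen, which hints at faster removal. However, none of the measured compounds carries its 3-hydroxyazetidin-1-yl group, so that hint is weak, and the measured steps set no firm direction. The expectation therefore stays near compound 3 51 mL.min-1.g-1, with wide uncertainty on both sides. The expected change is a 1.5-fold lower number from compound 3 to compound 4 (0.16 log units; within the scatter), so no clear shift beyond the scatter is anticipated. For compound 4 the estimated value is 35 mL.min-1.g-1, with an expected range from 14 mL.min-1.g-1 to 110 mL.min-1.g-1.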

Compound 4, intrinsic clearance in microsomes: 40 mL.min-1.g-1
Compound 4: the middle estimate sits 1.1-fold (0.06 log units) below what was measured; measured number inside the range.
By their numbers in this assay, from the lowest: compounds 4 and 3 (each within the scatter of the next); then compound 2. At a limit, below all of these: compound 1.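

The dimethylamino group of compound 2 and the 3-hydroxyazetidin-1-yl group of compound 4 both leave the amide without its hydrogen, yet this assay shows a 5.0-fold lower number from compound 2 to compound 4 (0.69 log units; beyond the scatter), so among these compounds a missing amide hydrogen does not by itself go with fast removal. Putting 3-hydroxyazetidin-1-yl in place of isopropylamino on the carbonyl carbon gives a 1.3-fold lower number from compound 3 to compound 4 (0.11 log units; within the scatter), so this assay cannot tell these two groups apart, even though one brings a four-membered ring and an oxygen that the other lacks. The step of an at least 2.8-fold higher number from compound 1 to compound 4 (0.45 log units; beyond the scatter) keeps methylamino as the group with the slowest removal of the four.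

As far as these compounds go, compound 1 gives a limit and not a number, so how far it lies under the others stays open: the limit of < 14 mL.min-1.g-1 in this assay, at which 1 of the 4 values shown sits. The compounds shown also do not separate the part played by the hydroxyl from that of the ring, and a plain azetidin-1-yl, a pyrrolidin-1-yl or a morpholin-4-yl group on the same carbonyl carbon would be needed to pull the two apart.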